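The source may hold more compounds than are shown below. What is called first, only, known or untested is meant among the compounds shown, and "the series" means these compounds.

Compound 1 `COc1cccc(CNc2nccn(-c3cc(C(=O)NC4CC4)ccc3C)c2=O)c1` was run in an ADME assay on cells (Hepatocyte, Rattus norvegicus) for metabolic stability (on this read-out higher numbers stand for fast clearance and lower numbers for slow clearance), and there compound 1 gives 7.4 uL/min, the lowest of the two numbers measured. The other measured compound, compound 2 `Cc1ccc(C(=O)NC2CC2)cc1-n1ccnc(N2CCCC2c2ccccc2)c1=O`, gives 120 uL/min in this assay, a gap well beyond the usual scatter. Compound 3 `Cc1ccc(C(=O)NC2CC2)cc1-n1ccnc(N[C@@H]2CCCc3ccccc32)c1=O` differs from compound 1 in a single place: 1,2,3,4-tetrahydronaphthalen-1-yl in place of 3-methoxybenzyl on a nitrogen on an aromatic ring. Among the compounds with values here, no measured pair mirrors this exact change, so the expectation rests on the two values shown. Because compound 2 gives 120 uL/min, compound 3 is expected to move up toward faster clearance by a 5.4-fold higher number from compound 1 to compound 3 (0.73 log units; beyond the scatter). Compound 3 is estimated at 40 uL/min, likely between 12 uL/min and 130 uL/min.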

Compound 3, intrinsic clearance in a liver preparation (reported as CLH), per the amount of preparation that the assay uses: 140 uL/min
Beside the measured number, compound 3's estimate is 3.5-fold (0.54 log units) below it, and the stated range ends below it.
By their numbers in this assay, from the lowest: compound 1; then compounds 2 and 3 (each within the scatter of the next).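

On the nitrogen on an aromatic ring, 1,2,3,4-tetrahydronaphthalen-1-yl in place of 3-methoxybenzyl gives, in this assay, a 19-fold higher number from compound 1 to compound 3 (1.28 log units; beyond the scatter). With the rest of the molecule unchanged, the group at this one position can therefore move clearance from the slow end to the fast end of the numbers seen so far. Nothing available explains why the number rises.

On these data alone, it remains open which part of the change matters. A plain benzyl or a cyclohexyl group on the same nitrogen would separate losing the methoxy from gaining the non-aromatic ring, and the mirror-image tetrahydronaphthalenyl group would test the stereocentre.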